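Swapping methyl for chloro on the (4-methylphenyl)amino arm

A few compounds are considered here, and "the series" means these few. Any claim that something is new, unique, unknown or untested is made for them only; others in the source may bear on it.

In a functional assay on the whole organism (strain Wister albino) for inhibition, with Rattus norvegicus as the target, read by paw edema, with stated times of 1 h and 4 h, at a dose of 50 mg/kg by the intraperitoneal route (on this read-out higher numbers stand for more inhibition at the one dose given (going by the name of the read-out) and lower numbers for less inhibition), compound 3 `CCOC(=O)c1c(-c2ccc(Cl)cc2)cc(-c2ccccc2)nc1Nc1ccc(C)cc1` gives 90.9%, the second highest of the three numbers measured. Compound 1 `CCOC(=O)c1c(-c2ccc(Cl)cc2)cc(-c2ccccc2)nc1N1CCCCC1` gives 103%, and the step of a number 12.1 percentage points lower from compound 1 to compound 3 (beyond the scatter) is modest. Compound 2 `CCOC(=O)c1c(-c2ccc(Cl)cc2)cc(-c2ccccc2)nc1N1CCN(C)CC1` gives 55.6%, so the step of a number 35.3 percentage points higher from compound 2 to compound 3 (beyond the scatter) is large, as is a number 47.4 percentage points lower from compound 1 to compound 2 (beyond the scatter).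

Compound 4 `CCOC(=O)c1c(-c2ccc(Cl)cc2)cc(-c2ccccc2)nc1Nc1ccc(Cl)cc1` is not yet measured. It differs from compound 3 in one place: chloro in place of methyl on an aromatic carbon, on an aromatic carbon of a six-membered aromatic ring of carbon only, para to a large group. For the measured compounds named here, none of the measured steps makes this same exchange; all three steps measured so far change the whole group attached to the core, and the exchange of one small substituent on the outer ring of that group has no measured counterpart. The measured steps show that this assay does respond strongly when the group on that aromatic carbon of the core is changed, but they give no direction for a methyl-to-chloro swap farther out. Compound 4 is therefore expected to sit near compound 3, with a step of a number 2.9 percentage points lower from compound 3 to compound 4 (within the scatter) that may well lie within the scatter. The estimate for compound 4 in this assay is 88%, in the range 70% to 104%.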

Compound 4, a percentage reported as inhibition, in the whole organism at one dose (the size of the read-out at that dose, not a potency): 95.9%
Compound 4: middle estimate off by 7.9 percentage points, on the low side; measured number inside the range.
By their numbers in this assay, from the lowest: compound 2; then compounds 3, 4 and 1 (each within the scatter of the next, the first and the last beyond it).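

In this assay, for the compounds shown here, the exchange of chloro for methyl on the outer ring, on an aromatic carbon para to a large group, gives the first measured step at this position (a number 5 percentage points higher from compound 3 to compound 4 (within the scatter)), so the two small groups cannot be told apart here. The exchange nevertheless alters how the arm compares with the other groups on the core: the (4-chlorophenyl)amino arm stays well clear of the 4-methylpiperazin-1-yl group (a number 40.3 percentage points higher from compound 2 to compound 4 (beyond the scatter)) and, unlike the (4-methylphenyl)amino arm of compound 3 (a number 12.1 percentage points lower from compound 1 to compound 3 (beyond the scatter)), it cannot be separated from the piperidin-1-yl group (a number 7.1 percentage points lower from compound 1 to compound 4 (within the scatter)). Nothing in the information available accounts for any of these steps.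

Going by these compounds, with only methyl and chloro at this carbon, it remains open whether a larger or differently built group there, such as methoxy, a carboxylic acid, an amine or a longer alkyl chain, would move the read-out beyond the scatter. The compounds also leave open what the plain phenylamino arm with only hydrogen at this carbon would give, and so whether either substituent matters at all.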